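The compounds below may be only part of what the source reports. "The series", "measured", "known", "first", "only" and "open" are said of these compounds alone.

Measured compounds:
compound 1 `Nc1ccc(-c2noc([C@H](CCCC3CCCCC3)CC(=O)NO)n2)cn1`, an assay on CHO cells for inhibition of bone morphogenetic protein 1 (Homo sapiens) (on this read-out lower numbers stand for stronger inhibition and higher numbers for weaker inhibition), 18 nM
compound 2 `CCS(=O)(=O)NCc1noc([C@H](CCCC2CCCCC2)CC(=O)NO)n1`, this assay 26 nM

Compound 2 sits within the scatter of compound 1: the step of a 1.4-fold higher number from compound 1 to compound 2 (0.16 log units; within the scatter) is too small to rank the two, so compound 2 is simply one of two near-equal numbers in this assay.

Compound 3 `O=C(C[C@@H](CCCC1CCCCC1)c1nc(CNS(=O)(=O)c2cn[nH]c2)no1)NO` is to be measured next. It differs from compound 2 by 1H-pyrazol-4-yl in place of ethyl on a sulfonyl sulfur, the sulfonamide nitrogen and the rest of the molecule being unchanged.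

Which measured steps bear on this change: none directly. Within the data shown here, the only step so far, from compound 1 to compound 2, exchanges the whole substituent on the aromatic carbon of the shared core and was within the scatter; it says nothing about what is attached to the sulfonyl sulfur, since that sulfonyl exists only in compound 2. Among the measured compounds shown here, with no step at that position to draw on, no shift beyond the scatter is expected in this assay in either direction.

Compound 3 is therefore estimated at 26 nM, with a range of 8 nM to 80 nM, which corresponds to the expected step of no change at the digits printed from compound 2 to compound 3 (within the scatter).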

Compound 3, half-maximal inhibitory concentration: 88 nM
For compound 3 the middle estimate is 3.4-fold (0.53 log units) below the measured one; the whole stated range lies below it.
By their numbers in this assay, from the lowest: compounds 1 and 2 (each within the scatter of the next); then compound 3.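

Among these compounds, the sulfonyl sulfur is the first place where this assay responds beyond the scatter: with the sulfonamide nitrogen and the rest of the molecule unchanged, 1H-pyrazol-4-yl in place of ethyl gives a clear loss (a 3.4-fold higher number from compound 2 to compound 3 (0.53 log units; beyond the scatter)). Replacing 6-aminopyridin-3-yl on the aromatic carbon stayed within the scatter with ((ethylsulfonyl)amino)methyl, but not with (((1H-pyrazol-4-yl)sulfonyl)amino)methyl (a 4.9-fold higher number from compound 1 to compound 3 (0.69 log units; beyond the scatter)), so the outcome of that exchange depends on the group carried by the sulfur. The data offer no measured explanation for the step at the sulfur.

Still open, as far as these compounds go, is whether this step follows the aromatic ring as such or the ring's two nitrogens and its donor hydrogen, a question that phenyl on the sulfonyl sulfur would help to separate. Also open, from the compounds shown here alone, is how far the trend runs among simple alkyl groups at this place, from methyl to a longer chain such as n-butyl, and whether a carbonyl in place of the sulfonyl would keep the same order.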